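Swapping a propyl chain for an ether-bearing chain on the core

The source may report more compounds than this note shows. Statements on the series, on what has been measured and on what is new or still open speak of the compounds shown alone.

Of the compounds shown here, two of one shared core have been tested in a functional assay on KB cells (Homo sapiens) for inhibition; a higher number here means a weaker inhibitor, a lower number a stronger inhibitor. Compound 1 `N#Cc1c(Br)n(COCc2ccccc2)c2ncnc(N)c12` reaches only a limit of the assay, giving > 100000 nM in this assay. That result of compound 1 is a limit (the limit of > 100000 nM in this assay, at which 1 of the 2 values shown sits). For the measured compounds named here, compound 2 `CCCn1c(N)c(C#N)c2c(N)ncnc21` gives a measured number, 15000 nM in this assay, and so stands as the only real value among the two results. Compound 3 `COCCOCn1c(N)c(C#N)c2c(N)ncnc21` has not yet been measured. It differs from compound 2 in one place: 2-methoxyethoxy in place of ethyl on a saturated chain carbon bound to an aromatic nitrogen. The change keeps the nitrile and both amino groups of the core untouched and only alters the chain that hangs from the aromatic nitrogen. Going by the values given here, with no measured step of this kind to lean on, the expected step from compound 2 to compound 3 is small, a 1.3-fold higher number from compound 2 to compound 3 (0.12 log units; within the scatter), within the usual scatter and in no clear direction. Compound 3 is therefore estimated to give 20000 nM in this assay, with a range from 5000 nM to 80000 nM.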

Compound 3, half-maximal inhibitory concentration: 210000 nM
The estimate for compound 3 lay 11-fold (1.02 log units) below the measured number, and the stated range ends below it.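

In this assay the chain on the aromatic nitrogen proves sensitive to change: 2-methoxyethoxy in place of ethyl on the saturated chain carbon brings a 14-fold higher number from compound 2 to compound 3 (1.15 log units; beyond the scatter) and so clearly weakens inhibition. For the compounds shown here, this is the first measured step at this position, and it shows that the propyl of compound 2 cannot be exchanged for (2-methoxyethoxy)methyl without a loss. Compound 1 adds no number to set beside this step, as its result is only a limit: the limit of > 100000 nM in this assay, at which 1 of the 3 values shown sits.

Nothing measured here accounts for the loss. From the compounds shown here alone, whether an all-carbon chain such as pentyl, or a chain ending in an amine, would keep the level of compound 2 remains open.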